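Sulfonyl guanidine series: benzyl sulfanyl variation, cytotoxicity

The source may report more compounds than this note shows. Statements on the series, on what has been measured and on what is new or still open speak of the compounds shown alone.

Measured so far:
- compound 1, `Cc1cc(-c2ccccc2)n(/C(N)=N/S(=O)(=O)c2cc(C)c(Cl)cc2SCc2ccccc2C)n1`, 80000 nM
- compound 2, `Cc1cc(-c2ccccc2)n(/C(N)=N/S(=O)(=O)c2cc(C)c(Cl)cc2SCc2ccccc2Cl)n1`, 135000 nM

In a functional assay on MCF7 cells (Homo sapiens) for cytotoxicity, read by MTT assay, with a stated time of 72 h (a lower number here means a stronger inhibitor, a higher number a weaker inhibitor), compound 2 gives 135000 nM, the highest of the two numbers in hand; its nearest neighbour is compound 1. Among the measured compounds shown here, the only step measured, a 1.7-fold higher number from compound 1 to compound 2 (0.23 log units; within the scatter), is within the scatter, so the two compounds are not separated by the data.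

Compound 3, `Cc1cccc(CSc2cc(Cl)c(C)cc2S(=O)(=O)/N=C(\N)n2nc(C)cc2-c2ccccc2)c1`, is not yet measured. Its change from compound 2 is 3-methylphenyl in place of 2-chlorophenyl on a saturated chain carbon bound to a sulfur. For the measured compounds named here, the one measured step bears on it only loosely: it swapped a substituent at the same part of the structure and moved the number little. Nothing in hand points to a gain or loss beyond the scatter, so the expected step of a 1.4-fold lower number from compound 2 to compound 3 (0.13 log units; within the scatter) is flat. The value of compound 3 in this assay is therefore expected at 100000 nM, within 40000 nM to 250000 nM.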

Compound 3, half-maximal inhibitory concentration: 105000 nM
The estimate for compound 3 lay 1.1-fold (0.02 log units) below the measured number; the range from low to high includes it.
By their numbers in this assay, from the lowest: compounds 1, 3 and 2 (each within the scatter of the next).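

In this assay, 3-methylphenyl in place of 2-chlorophenyl on the saturated chain carbon bound to a sulfur gives a 1.3-fold lower number from compound 2 to compound 3 (0.11 log units; within the scatter) and 3-methylphenyl in place of 2-methylphenyl at that same place gives a 1.3-fold higher number from compound 1 to compound 3 (0.12 log units; within the scatter) so both steps stay within the scatter. The second step adds a comparison that the earlier pair did not offer: 2-methylphenyl and 3-methylphenyl are not separated by this assay, just as the chloro and methyl compounds were not. No measured evidence bears on why these three aryl groups read alike.

Still open, on these data alone, is whether an amine or a carboxylic acid on this phenyl ring would give a step beyond the scatter. A longer chain between the sulfur and the phenyl ring is equally untested among the compounds shown here.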